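Changing the amide side chain of compound 3

The source may hold more compounds than are shown below. What is called first, only, known or untested is meant among the compounds shown, and "the series" means these compounds.

Values in a functional assay on PC-3 cells (Homo sapiens) for antiproliferative activity, read by MTT assay, with a stated time of 24 h (a higher number here means a weaker inhibitor, a lower number a stronger inhibitor), are:
- compound 1 `CCn1c(C(=O)N[C@@H](C)C(=O)OC)ccc1C(CC)(CC)c1ccc(OCS(=O)(=O)c2ccccc2)c(C)c1` gives > 50000 nM as a limit
- compound 2 `CCn1c(C(=O)N[C@H](C)C(=O)OC)ccc1C(CC)(CC)c1ccc(OCS(=O)(=O)c2ccccc2)c(C)c1` gives > 50000 nM as a limit
- compound 3 `CCn1c(C(=O)N[C@@H](CO)C(C)C)ccc1C(CC)(CC)c1ccc(OCS(=O)(=O)c2ccccc2)c(C)c1` gives 10600 nM as a measured number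

Going by the values given here, compound 3 holds the only true number here, since the other two values are limits. Compound 4 `CCn1c(C(=O)N[C@H](CO)CCO)ccc1C(CC)(CC)c1ccc(OCS(=O)(=O)c2ccccc2)c(C)c1` alters one group of compound 3, and the change is 3-hydroxy-1-(hydroxymethyl)propyl in place of 1-(hydroxymethyl)-2-methylpropyl on an amide-type nitrogen on an amide-type nitrogen. Two measured steps alter the group on that same nitrogen, namely an at least 4.7-fold lower number from compound 1 to compound 3 (0.67 log units; beyond the scatter) and an at least 4.7-fold lower number from compound 2 to compound 3 (0.67 log units; beyond the scatter), so this place can move the number. Among the compounds with values here, neither is the same swap as the one in compound 4. There is also a step that the two limits leave unreadable from compound 1 to compound 2 and it gives no guide. Compound 3 alone carries 1-(hydroxymethyl)-2-methylpropyl and gives 10600 nM here, so losing that group points to a somewhat higher number, meaning a weaker inhibitor. The expected change is a 2.4-fold higher number from compound 3 to compound 4 (0.37 log units; beyond the scatter) on this uncertain basis. In this assay the estimated value for compound 4 is 25000 nM with an expected range from 9000 nM to 50000 nM at this stage.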

Compound 4, half-maximal inhibitory concentration: 12100 nM
Compound 4: the middle estimate sits 2.1-fold (0.32 log units) above what was measured, and the stated range covers the measured number.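

In this assay, the swap on the amide-type nitrogen gives a 1.1-fold higher number from compound 3 to compound 4 (0.06 log units; within the scatter), so the number does not depend on keeping 1-(hydroxymethyl)-2-methylpropyl, and a group with 2 hydrogen-bond donors in place of 1 serves equally well here. 3-Hydroxy-1-(hydroxymethyl)propyl also stands clear of 1-(methoxycarbonyl)ethyl, with an at least 4.1-fold lower number from compound 2 to compound 4 (0.61 log units; beyond the scatter) and an at least 4.1-fold lower number from compound 1 to compound 4 (0.61 log units; beyond the scatter). These two steps start from a limit and not from a true number, so their full size cannot be read: the limit of > 50000 nM in this assay, at which 2 of the 4 values shown sit.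

Both groups with a measured number carry hydroxymethyl, and the compounds shown do not tell whether that hydroxyl is what separates them from the two methyl esters. A carboxylic acid or an amine on this nitrogen, or a longer chain ending in hydroxyl, would help to settle that.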